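Tetrazole hydrazide series: a fluoro step from compound 3

The compounds below may be only part of what the source reports. "The series", "measured", "known", "first", "only" and "open" are said of these compounds alone.

Measured so far:
compound 1 `Cn1nnnc1SCC(=O)N/N=c1/scc(-c2ccccc2)n1-c1ccccc1` gives 56.2%
compound 2 `O=C(CSc1ncccn1)N/N=c1/scc(-c2ccc(Br)cc2)n1-c1ccccc1` gives 69%
compound 3 `O=C(CSc1nnnn1-c1ccccc1)N/N=c1/scc(-c2ccccc2)n1-c1ccccc1` gives 36.7%

In a functional assay on C6 cells (Rattus norvegicus) for cytotoxicity, read by MTT assay, with a stated time of 24 h, tested at 50 ug/mL (on this read-out lower numbers stand for a stronger effect and higher numbers for a weaker effect at the one concentration tested), compound 3 holds the lowest of the three numbers, that is the strongest effect seen; compound 1 sits higher and compound 2 higher still, both beyond the scatter. Within the data shown here, the only step measured in one place is a number 19.5 percentage points lower from compound 1 to compound 3 (beyond the scatter), a modest move downward.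

Compound 4 `O=C(CSc1nnnn1-c1ccccc1)N/N=c1/scc(-c2ccc(F)cc2)n1-c1ccccc1` differs from compound 3 by fluoro in place of hydrogen on an aromatic carbon. Among the measured compounds shown here, no measured step covers this change. For the measured compounds named here, compound 2 carries a bromo on the same ring, but it also differs from compound 1 elsewhere, so its value and that of compound 1 show only that two changes together gave a higher number; they say nothing about one fluoro on its own. Going by the values given here, with no direct precedent, the expectation for compound 4 is a step of a number 0.3 percentage points higher from compound 3 to compound 4 (within the scatter), which is expected to fall within the scatter. Compound 4 is therefore estimated at 37%, with a range from 22% to 52%.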

Compound 4, a percentage reported as activity, at one concentration (the size of the read-out at that concentration, not a potency): 43.7%
Beside the measured number, compound 4's estimate is 6.7 percentage points below it; the measured number falls inside the stated range.
By their numbers in this assay, from the lowest: compounds 3 and 4 (each within the scatter of the next); then compound 1; then compound 2.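

In this assay the change from phenyl to 4-fluorophenyl gives a number 7 percentage points higher from compound 3 to compound 4 (within the scatter) and so leaves compound 3 and compound 4 indistinguishable at the one concentration tested. Among these compounds, this is the first reading of a single change on this ring, and it shows that this aromatic carbon takes a fluoro without a step beyond the scatter. No evidence bears on the cause of this outcome.

From the compounds shown here alone, whether bromo on its own, or a methoxy, an amine or a carboxylic acid at this place, would stay within the scatter of compound 3 remains open. Also open, going by these compounds, is whether the closeness of compound 3 and compound 4 holds at other concentrations, or with methyl in place of phenyl on the aromatic nitrogen, as in compound 1.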